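Same Ring Swap Tested Beside a Different Benzyl Group

The source may hold more compounds than are shown below. What is called first, only, known or untested is meant among the compounds shown, and "the series" means these compounds.

In an assay on HEK293 cells for displacement of a labelled ligand from Orexin receptor type 2 (Homo sapiens), read by scintillation counting, with a stated time of 90 min (a lower number here means a stronger inhibitor, a higher number a weaker inhibitor), three compounds have been measured:
compound 1 `COc1cc(F)c(CN2C(=O)N(c3cc(OC)nc(OC)c3)S(=O)(=O)c3ccccc32)c(F)c1` gives 0.251 nM;
compound 2 `COc1ccc(N2C(=O)N(Cc3c(F)cc(F)cc3F)c3ccccc3S2(=O)=O)cc1OC` gives 2 nM;
compound 3 `COc1cc(F)c(CN2C(=O)N(c3ccc(OC)c(OC)c3)S(=O)(=O)c3ccccc32)c(F)c1` gives 0.501 nM.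

Compound 3 and compound 1 differ only in one ring: 2,6-dimethoxypyridin-4-yl in place of 3,4-dimethoxyphenyl on an amide-type nitrogen in a ring. That change gave a 2.0-fold lower number from compound 3 to compound 1 (0.30 log units; within the scatter). Compound 2 and compound 3 share a core that differs in one small group: fluoro in place of methoxy on an aromatic carbon, and in this assay this gave a 4.0-fold lower number from compound 2 to compound 3 (0.60 log units; beyond the scatter).

Compound 4 `COc1cc(N2C(=O)N(Cc3c(F)cc(F)cc3F)c3ccccc3S2(=O)=O)cc(OC)n1` carries the same kind of change relative to compound 2: 2,6-dimethoxypyridin-4-yl in place of 3,4-dimethoxyphenyl on an amide-type nitrogen in a ring. The surroundings are not identical, since the ring atom here bears a 2,4,6-trifluorobenzyl group rather than a 2,6-difluoro-4-methoxybenzyl group. Because a 2.0-fold lower number from compound 3 to compound 1 (0.30 log units; within the scatter) was small, the step is expected to be a 2.0-fold lower number from compound 2 to compound 4 (0.30 log units; within the scatter). Compound 4 is therefore estimated to give 1 nM, between 0.45 nM and 2.5 nM.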

Compound 4, inhibition constant: 1.26 nM
Beside the measured number, compound 4's estimate is 1.3-fold (0.10 log units) below it; the measured number falls inside the stated range.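

Replacing 3,4-dimethoxyphenyl with 2,6-dimethoxypyridin-4-yl gave a 1.6-fold lower number from compound 2 to compound 4 (0.20 log units; within the scatter), a step much the same size as on the other core: the same change on two cores in this assay, a 2.0-fold lower number (0.30 log units; within the scatter) from compound 3 to compound 1 and a 1.6-fold lower number (0.20 log units; within the scatter) from compound 2 to compound 4, 1.3-fold (0.10 log units) apart, within the scatter of two such steps. The change in the small group on the benzyl ring also carried across, with fluoro in place of methoxy giving a 5.0-fold higher number from compound 1 to compound 4 (0.70 log units; beyond the scatter), the reverse of the same change matching in size on the other pair: the same change on two cores in this assay, a 4.0-fold lower number (0.60 log units; beyond the scatter) from compound 2 to compound 3 and a 5.0-fold lower number (0.70 log units; beyond the scatter) from compound 4 to compound 1, 1.3-fold (0.10 log units) apart, within the scatter of two such steps. Each change therefore behaved alike on these two cores, but both ring-swap steps lie within the scatter, so a real effect of that swap is not shown, and two cores cannot speak for the whole series.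

Still open, as far as these compounds go, is how an amine or a carboxylic acid on the dimethoxy ring would fare. The same holds for a longer chain on the benzyl ring.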